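The compounds below may be only part of what the source reports. "The series", "measured", "known", "first", "only" and "open" are said of these compounds alone.

Measured in a functional assay on PC-3 cells (Homo sapiens) for cytotoxicity, read by MTT assay, with a stated time of 72 h; on this read-out higher numbers stand for weaker inhibition and lower numbers for stronger inhibition:
compound 1 `O=C(Nc1ccc(Oc2ccnc3[nH]ccc23)cc1)c1nn(-c2ccc(Cl)cc2)ccc1=O`: 32400 nM
compound 2 `O=C(Nc1ccc(Oc2ccnc3[nH]ccc23)cc1)c1nn(-c2ccccc2)ccc1=O`: 15000 nM
compound 3 `O=C(Nc1ccc(Oc2ccnc3[nH]ccc23)cc1)c1nn(-c2ccc(Br)cc2F)ccc1=O`: 12800 nM

Compound 1 gives the highest number of the three. The two measured steps away from it are modest: a 2.2-fold lower number from compound 1 to compound 2 (0.33 log units; beyond the scatter) and a 2.5-fold lower number from compound 1 to compound 3 (0.40 log units; beyond the scatter), while a 1.2-fold lower number from compound 2 to compound 3 (0.07 log units; within the scatter) stays within the scatter. All three measured steps change the aryl group on the aromatic nitrogen of the pyridazinone, not the fused system.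

Compound 4 `Cn1ccc2c(Oc3ccc(NC(=O)c4nn(-c5ccc(Cl)cc5)ccc4=O)cc3)ccnc21` differs from compound 1 by methyl in place of hydrogen on an aromatic nitrogen. Among the compounds with values here, no measured step touches this position, so none bears on it; the expectation rests on the scatter alone. No step beyond the scatter is expected, a 1.1-fold higher number from compound 1 to compound 4 (0.03 log units; within the scatter), with a wide range. For compound 4 in this assay the estimate is 35000 nM, between 12000 nM and 110000 nM.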

Compound 4, half-maximal inhibitory concentration: > 60000 nM
Compound 4: no number, only a limit; the forecaster's own chance of this, stated with the estimate: 25%; middle value at least 1.7-fold (0.23 log units) away from the limit.
By their numbers in this assay, from the lowest: compounds 3 and 2 (each within the scatter of the next); then compound 1. At a limit, above all of these: compound 4.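

In this assay, methyl in place of hydrogen on the aromatic nitrogen of the five-membered ring is the first change shown in the fused system, and it gives an at least 1.8-fold higher number from compound 1 to compound 4 (0.26 log units; that floor lies within the scatter). On these data alone, compound 4 has no number, only a limit of the assay: the limit of > 60000 nM in this assay, at which 1 of the 4 values shown sits. The true size of this step therefore stays unknown, though the methyl brings no lower number.

Open, as far as these compounds go, is how an ethyl group, a longer chain or a chain ending in an amine would read on this nitrogen. Also open, from the compounds shown here alone, is whether the methyl step holds with phenyl or 4-bromo-2-fluorophenyl on the other aromatic nitrogen.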